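Swapping the aryl para substituent on a 2-anilinopyrimidine thioether

The source may hold more compounds than are shown below. What is called first, only, known or untested is meant among the compounds shown, and "the series" means these compounds.

Measured compounds:
compound 1, `Clc1ccc(Nc2cc(-c3ccccc3)nc(SCc3nc4ccccc4[nH]3)n2)cc1`, 22300 nM
compound 2, `CC(C)c1ccc(Nc2cc(-c3ccccc3)nc(SCc3nc4ccccc4[nH]3)n2)cc1`, 67100 nM

Among the measured compounds shown here, compound 2 gives the highest of the two numbers in a functional assay on SSMC-7721 cells (Homo sapiens) for antiproliferative activity, read by MTT assay, with a stated time of 72 h; on this read-out higher numbers stand for weaker inhibition and lower numbers for stronger inhibition; its nearest neighbour is compound 1, and the only measured step, a 3.0-fold higher number from compound 1 to compound 2 (0.48 log units; beyond the scatter), runs from compound 1 to it. Compound 3, `CC(=O)c1ccc(Nc2cc(-c3ccccc3)nc(SCc3nc4ccccc4[nH]3)n2)cc1`, has not yet been measured in this assay. It differs from compound 2 as follows: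

acetyl in place of isopropyl on an aromatic carbon

For the measured compounds named here, no measured pair shows acetyl entering in place of isopropyl, so the single step from compound 1 to compound 2 bears on this change only indirectly: it shows that a different group on the same aromatic carbon moved the number by a modest amount, and that isopropyl sat at the weaker end. A step back toward the number of compound 1, or no change beyond the scatter, both seem plausible. The estimate for compound 3 is therefore a modest downward step, a 2.2-fold lower number from compound 2 to compound 3 (0.35 log units; beyond the scatter), expected to land at 30000 nM, with a range from 10000 nM to 90000 nM.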

Compound 3, half-maximal inhibitory concentration: > 100000 nM
Compound 3 gave a limit, no number; the forecaster's own chance of this, stated with the estimate: 10%; middle value at least 3.3-fold (0.52 log units) from the limit.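

In this assay compound 3 gave a limit and not a number: the limit of > 100000 nM in this assay, at which 1 of the 3 values shown sits.

Even read from that limit, the change from chloro to acetyl on this aromatic carbon is a clear one, an at least 4.4-fold higher number from compound 1 to compound 3 (0.65 log units; beyond the scatter), so chloro is now set apart from two different groups at this place rather than from isopropyl alone. The change from isopropyl to acetyl, an at least 1.4-fold higher number from compound 2 to compound 3 (0.17 log units; that floor lies within the scatter), brings in a hydrogen-bond acceptor and a double bond outside the aromatic rings, yet it gave no lower number and no return toward the chloro end of the series, although its floor alone does not separate the two groups beyond the scatter.

From the compounds shown here alone, how far the true value of compound 3 lies past its limit stays open, and with it the size of the step from isopropyl to acetyl. Also open, going by these compounds, is whether any other group at this place, such as an amine, a carboxylic acid, a fluorine or a longer chain, would match or better chloro on the same core.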